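This account rests on a few compounds, and the source may have more. Where it says the series, first, only, none or still open, it means among the compounds named here.

Working notes on the series. In a functional assay on KYSE-410 cells (Homo sapiens) for antiproliferative activity, read by MTT assay, with a stated time of 72 h (a lower number here means a stronger inhibitor, a higher number a weaker inhibitor), compound 1 `O=C(c1cc(=O)[nH]c2cc(Br)ccc12)N1CCCCC1` gives a value that is an assay limit, > 20000 nM. Compound 2 `O=C(Nc1cccc(Cl)c1)c1cc(=O)[nH]c2cc(Br)ccc12` likewise returns a limit in this assay, > 20000 nM. Within the data shown here, compound 3 `COc1ccc(-c2ccc3c(C(=O)Nc4cccc(F)c4)cc(=O)[nH]c3c2)cc1` is the one member with a measured number: in this assay compound 3 gives 18000 nM. Among the three values shown it stands as the only number; the other two are the limit of > 20000 nM in this assay, at which 2 of the 3 values shown sit, so compound 3 can be set against them only in that its value is a number where theirs are limits. Compound 4 `O=C(Nc1cccc(F)c1)c1cc(=O)[nH]c2cc(-c3cccnc3F)ccc12` has not yet been measured in this assay. It differs from compound 3 in one place: 2-fluoropyridin-3-yl in place of 4-methoxyphenyl on an aromatic carbon. Among the measured compounds shown here, no step between measured compounds exists to guide this change, and the weak value of compound 3 leaves little room for a large move downward. The change is expected to be small, a 1.1-fold higher number from compound 3 to compound 4 (0.05 log units; within the scatter), within the usual scatter in either direction. Compound 4 is therefore expected to give about 20000 nM in this assay, in the range 8000 nM to 40000 nM, with a fair chance that only a limit is reported.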

Compound 4, half-maximal inhibitory concentration: 11600 nM
Compound 4: the middle estimate sits 1.7-fold (0.24 log units) above what was measured; the measured number falls inside the stated range.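

Among these compounds, at this aromatic carbon of the shared core, 2-fluoropyridin-3-yl in place of 4-methoxyphenyl gives a 1.6-fold lower number from compound 3 to compound 4 (0.19 log units; within the scatter) in this assay, the first step that can be read between two measured compounds. The exchange of a ring of carbon only for a ring with one hetero atom and a fluorine therefore leaves the number within the scatter, so the two groups cannot be told apart at this position. The series still holds more limits than step-forming numbers: the limit of > 20000 nM in this assay, at which 2 of the 4 values shown sit.

From the compounds shown here alone, whether an amine, a carboxylic acid or a longer alkyl chain at this carbon would move the number beyond the scatter stays open. Steps to compound 1 and compound 2 cannot be read, and what the amide part contributes remains unresolved.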